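Hydrazone carboxylic acids: fluoro to isopropyl step

A few compounds are considered here, and "the series" means these few. Any claim that something is new, unique, unknown or untested is made for them only; others in the source may bear on it.

Three members of this series have numbers in a functional assay (mast cells) for inhibition, with Rattus norvegicus as the target; on this read-out lower numbers stand for an effect already at smaller amounts and higher numbers for an effect only at larger amounts of compound. Compound 1 `CC1CC/C(=N\Nc2cccc(C(=O)O)c2)c2nccc(=O)n21` gives 655000 nM in this assay. Compound 2 `CC1CCn2c(ncc(C(=O)O)c2=O)/C1=N/Nc1ccccc1` gives 5400 nM. Compound 3 `CC1CC/C(=N\Nc2ccc(F)cc2)c2ncc(C(=O)O)c(=O)n21` gives 1200 nM, the lowest number of the three; the gap from compound 3 to compound 2 is beyond the scatter, and the gap to compound 1 is far beyond it, so compound 3 stands as the most potent measured member.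

The next compound, compound 4 `CC(C)c1ccc(N/N=C2\CCC(C)n3c2ncc(C(=O)O)c3=O)cc1`, differs from compound 3 in one place: isopropyl in place of fluoro on an aromatic carbon. Going by the values given here, no step between two measured compounds mirrors this change, so nothing in the measured set shows what an isopropyl in place of fluoro does here. The remaining structure, including the carboxylic acid on the shared core, is kept.

Among the compounds with values here, with no directly comparable step, the step from compound 3 to compound 4 is expected to be small, within or close to the scatter, in either direction; the estimate is a 1.3-fold higher number from compound 3 to compound 4 (0.10 log units; within the scatter). For compound 4 in this assay the estimated value is 1500 nM, with a range from 300 nM to 8000 nM reflecting the lack of a guiding comparison.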

Compound 4, half-maximal effective concentration: 1200 nM
Compound 4: the middle estimate sits 1.3-fold (0.10 log units) above what was measured; low and high end bracket the measured number.
By their numbers in this assay, from the lowest: compounds 3 and 4 (each within the scatter of the next); then compound 2; then compound 1.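

In this assay, going by these compounds alone, isopropyl in place of fluoro on an aromatic carbon, para to a large group, gives no change at the digits printed from compound 3 to compound 4 (within the scatter), the first reading of any change at this position. The swap takes one fluorine out and puts three carbon heavy atoms in, with no ring, no hydrogen-bond donor or acceptor and no net charge on either side, and the number stays where it was. So this position, with the carboxylic acid on the shared core kept, carries either group without a shift beyond the scatter, although this rests on a single pair and no reason for it can be given from the data at hand.

The compounds shown leave open whether the same holds for an amine, a hydroxyl or a longer chain at this place, since fluoro and isopropyl are the only two groups compared here. They also leave open whether the isopropyl behaves the same way on a core without the carboxylic acid, or at another carbon of the same aromatic ring.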